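Nitro in Place of Methoxy: Another Limit Expected

The source may hold more compounds than are shown below. What is called first, only, known or untested is meant among the compounds shown, and "the series" means these compounds.

Compound 3 `COc1ccc(/C(C)=N/NC(=S)NC(C)(C)[C@H]2CC=C(C)CC2)cc1` carries a methoxy on its aromatic ring; in a functional assay on OVCAR-3 cells (Homo sapiens) for inhibition, read by sulforhodamine B assay, with a stated time of 48 h (on this read-out lower numbers stand for stronger inhibition of growth and higher numbers for weaker inhibition of growth), compound 3 reaches only the limit > 100000 nM. Compound 2 `CC1=CC[C@H](C(C)(C)NC(=S)N/N=C(\C)c2ccccc2)CC1` likewise stops at the limit > 100000 nM in this assay, so a step that the two limits leave unreadable from compound 2 to compound 3 cannot be read. Compound 1 `CC1=CC[C@H](C(C)(C)NC(=S)N/N=C/c2cccc(Cl)c2)CC1` gives 80500 nM in this assay. Compound 4 `CC1=CC[C@H](C(C)(C)NC(=S)N/N=C(\C)c2ccc([N+](=O)[O-])cc2)CC1` differs from compound 3 by nitro in place of methoxy on an aromatic carbon. Among the compounds with values here, no measured pair covers this exchange; the only one-place step, a step that the two limits leave unreadable from compound 2 to compound 3, is unreadable, and the limit of > 100000 nM in this assay, at which 2 of the 3 values shown sit, leaves compound 2 and compound 3 without a number. No step beyond the scatter is therefore expected, a number no higher from compound 3 to compound 4 (the limit leaves the size open). Compound 4 is accordingly estimated at 100000 nM in this assay, between 40000 nM and 250000 nM, and is most likely to be reported again as a limit.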

Compound 4, concentration for total growth inhibition: 29300 nM
The estimate for compound 4 lay 3.4-fold (0.53 log units) above the measured number; the whole stated range lies above it.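

In this assay, nitro on the aromatic carbon para to a large group brings a clear gain: nitro in place of methoxy gives an at least 3.4-fold lower number from compound 3 to compound 4 (0.53 log units; beyond the scatter), and nitro in place of hydrogen gives an at least 3.4-fold lower number from compound 2 to compound 4 (0.53 log units; beyond the scatter). This shows that the group at this position can change the read-out, which the earlier unreadable step could not show. Both sizes remain open-ended, because the starting compounds have no number: the limit of > 100000 nM in this assay, at which 2 of the 4 values shown sit.

As far as these compounds go, whether an amine or a carboxylic acid at this position would also lower the number remains open.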